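Sulfonyl substituent and microsomal stability in the series

A few compounds are considered here, and "the series" means these few. Any claim that something is new, unique, unknown or untested is made for them only; others in the source may bear on it.

Compound 3 `O=C(NS(=O)(=O)c1ccccc1)c1ccc(Nc2nc(NC3(c4ccc(Cl)cc4)CC3)nc(OCC(F)(F)F)n2)cc1` holds the highest number of the three measured in an ADME assay on microsomes from liver (Homo sapiens) for metabolic stability, with a stated time of 10 min (on this read-out lower numbers stand for a less stable compound and higher numbers for a more stable compound), where compound 3 gives 100%. The two other measured members carry an ethyl chain on the sulfonyl sulfur instead of phenyl: compound 1 `CC(C)NCCS(=O)(=O)NC(=O)c1ccc(Nc2nc(NC3(c4ccc(Cl)cc4)CC3)nc(OCC(F)(F)F)n2)cc1` gives 89% in this assay, and compound 2 `CC(C)C(=O)NCCS(=O)(=O)NC(=O)c1ccc(Nc2nc(NC3(c4ccc(Cl)cc4)CC3)nc(OCC(F)(F)F)n2)cc1` gives 86%. The steps up to compound 3 read a number 11 percentage points higher from compound 1 to compound 3 (beyond the scatter) and a number 14 percentage points higher from compound 2 to compound 3 (beyond the scatter), while the change between the two chain-bearing compounds, a number 3 percentage points lower from compound 1 to compound 2 (within the scatter), stays within the scatter.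

Compound 4 `CNC(=O)NCCS(=O)(=O)NC(=O)c1ccc(Nc2nc(NC3(c4ccc(Cl)cc4)CC3)nc(OCC(F)(F)F)n2)cc1` differs from compound 3 by 2-((methylcarbamoyl)amino)ethyl in place of phenyl on a sulfonyl sulfur. This runs the two measured steps onto compound 3 in reverse: both of those replaced an ethyl-linked chain with phenyl and gained modestly. Among the compounds with values here, the chain in compound 4 ends in a methylcarbamoyl group rather than the isopropyl of compound 1 or the isopropylcarbonyl of compound 2, and no measured step covers that group itself. A modest step down beyond the scatter is therefore expected: a number 14 percentage points lower from compound 3 to compound 4 (beyond the scatter). For compound 4 the estimated value in this assay is 86%, with a range from 74% to 96%.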

Compound 4, percent of the compound remaining: 97%
Compound 4: the middle estimate sits 11 percentage points below what was measured, and the stated range ends below it.
By their numbers in this assay, from the lowest: compounds 2, 1, 4 and 3 (each within the scatter of the next, the first and the last beyond it).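

In this assay, the step of a number 3 percentage points lower from compound 3 to compound 4 (within the scatter) shows that phenyl on the sulfonyl sulfur is not needed to reach the top of this set, so the modest gains on moving to phenyl from the chains of compound 1 and compound 2 do not extend to every ethyl-linked chain. The end of the chain now separates members: methylamino in place of isopropyl on a carbonyl carbon gives a number 11 percentage points higher from compound 2 to compound 4 (beyond the scatter), but compound 1 does not separate, with methylcarbamoyl in place of isopropyl on an amine nitrogen giving a number 8 percentage points higher from compound 1 to compound 4 (within the scatter) as its step. Nothing on hand accounts for these steps.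

Open, going by these compounds, is whether a carboxylic acid at the chain end would match the methylcarbamoyl group. A longer chain between the sulfonyl sulfur and that group is equally unresolved.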